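Replacing One Nitrile With a Butyl Chain

The compounds below may be only part of what the source reports. "The series", "measured", "known", "first", "only" and "open" are said of these compounds alone.

Measured so far:
compound 1 `N#Cc1cccc(C#Cc2cccc(C#N)n2)c1`: 8.2 nM
compound 2 `N#Cc1cc(F)cc(C#Cc2cccc(C#N)n2)c1`: 2.7 nM
compound 3 `N#Cc1cccc(C#Cc2cccc(C(N)=O)c2)n1`: only a limit, > 10000 nM

In an assay on membranes from brain (strain Sprague-Dawley) for displacement of a labelled ligand from metabotropic glutamate receptor 5 (Rattus norvegicus), read by scintillation counting, with a stated time of 60 min (on this read-out higher numbers stand for weaker inhibition and lower numbers for stronger inhibition), compound 1 stands highest of the two numbers; the nearest is compound 2, reached by a 3.0-fold lower number from compound 1 to compound 2 (0.48 log units; beyond the scatter). Compound 3 sits at the limit of > 10000 nM in this assay, at which 1 of the 3 values shown sits.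

Compound 4 `CCCCc1cccc(C#Cc2cccc(C#N)c2)n1` differs from compound 1 by butyl in place of cyano on an aromatic carbon. Within the data shown here, the step that bears on it is the one to compound 3, where cyano also gave way to another group and the number rose by an at least 1200-fold higher number from compound 1 to compound 3 (3.08 log units; beyond the scatter). A large step upward, weaker inhibition, is therefore expected for compound 4, estimated at 2500 nM (range 250 nM to 10000 nM), which would mean a 300-fold higher number from compound 1 to compound 4 (2.48 log units; beyond the scatter).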

Compound 4, inhibition constant: 45 nM
Compound 4: the middle estimate sits 56-fold (1.74 log units) above what was measured; the measured number lies below the stated range.
By their numbers in this assay, from the lowest: compound 2; then compound 1; then compound 4. At a limit, above all of these: compound 3.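

The nitrile next to the ring nitrogen can be given up: with butyl in its place, a 5.5-fold higher number from compound 1 to compound 4 (0.74 log units; beyond the scatter) in this assay is only a modest step. Compound 3 has its value as a limit, > 10000 nM and carries its change on the other nitrile, so it does not speak for this place. No measurement shown explains why butyl is tolerated here.

On these data alone, whether a shorter chain such as methyl, an amine or a carboxylic acid would fare as well at this place remains open.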